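A few compounds are considered here, and "the series" means these few. Any claim that something is new, unique, unknown or untested is made for them only; others in the source may bear on it.

Three related compounds have been tested in a functional assay on MCF7 cells (Homo sapiens) for antiproliferative activity, read by MTT assay, with a stated time of 48 h (on this read-out higher numbers stand for weaker inhibition and lower numbers for stronger inhibition), and a fourth awaits its result.

Compound 3, `O=C(/C=C/c1ccc(F)cc1)Nc1nnc(-c2ccc(Cl)cc2)s1`, gives 1.58 ug/mL in this assay. Compound 1, `COc1ccc(-c2nnc(NC(=O)/C=C/c3ccc(F)cc3)s2)cc1`, carries one change relative to compound 3: methoxy in place of chloro on an aromatic carbon. In this assay compound 1 gives 0.85 ug/mL, and the step is a 1.9-fold lower number from compound 3 to compound 1 (0.27 log units; within the scatter).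

Compound 2, `O=C(/C=C/c1ccc(C(F)(F)F)cc1)Nc1nnc(-c2ccc(Cl)cc2)s1`, differs from compound 3 at the other end of the molecule: trifluoromethyl in place of fluoro on an aromatic carbon. In this assay compound 2 gives 1.65 ug/mL, and the step is a 1.0-fold lower number from compound 2 to compound 3 (0.02 log units; within the scatter). Compound 2 and compound 3 therefore stand together within the usual scatter of this read-out, so nothing separates them.

Compound 4, `COc1ccc(-c2nnc(NC(=O)/C=C/c3ccc(C(F)(F)F)cc3)s2)cc1`, has not yet been measured. It differs from compound 2 by methoxy in place of chloro on an aromatic carbon. This is the same change that turned compound 3 into compound 1, and the place described for it is the same, word for word, in both pairs; what differs between the two cores is the difference already given between compound 3 and compound 2.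

For the measured compounds named here, since the one earlier example of this change gave a 1.9-fold lower number from compound 3 to compound 1 (0.27 log units; within the scatter), the step from compound 2 to compound 4 is expected to be of similar size, a 1.8-fold lower number from compound 2 to compound 4 (0.26 log units; within the scatter). This rests on a single pair, so the expectation carries the scatter of that measurement. For compound 4 in this assay the estimate is 0.9 ug/mL, with a likely range from 0.45 ug/mL to 1.8 ug/mL.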

Compound 4, half-maximal inhibitory concentration: 0.79 ug/mL
Compound 4: middle estimate off by 1.1-fold (0.06 log units), on the high side; measured number inside the range.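

In this assay, methoxy in place of chloro gives a 2.1-fold lower number from compound 2 to compound 4 (0.32 log units; beyond the scatter), and set beside the earlier example, this change carries over from one core to the other with a step of much the same size: the same change on two cores in this assay, a 1.9-fold lower number (0.27 log units; within the scatter) from compound 3 to compound 1 and a 2.1-fold lower number (0.32 log units; beyond the scatter) from compound 2 to compound 4, 1.1-fold (0.05 log units) apart, within the scatter of two such steps. Trifluoromethyl in place of fluoro gives a 1.1-fold lower number from compound 1 to compound 4 (0.03 log units; within the scatter), so compound 1 and compound 4 stand together, and this change too reads alike on both cores: the same change on two cores in this assay, a 1.0-fold lower number (0.02 log units; within the scatter) from compound 2 to compound 3 and a 1.1-fold higher number (0.03 log units; within the scatter) from compound 4 to compound 1, 1.1-fold (0.05 log units) apart, within the scatter of two such steps. These four compounds form a single square of two changes, so they show that the two changes behaved independently of each other here, but they do not show that the methoxy step would hold on a more different core, and they do not explain why it arises.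

The compounds shown leave open what other groups would do on the same aromatic carbon in place of chloro or methoxy, such as an amine, a carboxylic acid or a longer chain. They also leave open whether the same steps would appear in cell lines other than this one, since every number here comes from a single assay.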